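A Shorter Link to the Carboxyphenyl Group

The compounds below may be only part of what the source reports. "The series", "measured", "known", "first", "only" and "open" are said of these compounds alone.

Compound 1, `Cc1c(OCCCCOCOc2ccc(C(=O)O)cc2)ccc(C(=O)CC2CCCC2)c1O`, is one of two compounds with a number in an assay on HEK293 cells for positive allosteric modulation of metabotropic glutamate receptor 3 (Rattus norvegicus), read by thallium flux, with a stated time of 2.5 min; on this read-out higher numbers stand for an effect only at larger amounts of compound and lower numbers for an effect already at smaller amounts; there compound 1 gives 1910 nM. Compound 3, `Cc1c(OCCCCOc2ccc(C(=O)O)c(Cl)c2)ccc(C(=O)CC(C)C)c1O`, gives 2050 nM in this assay, and the two values lie within the scatter of each other. For compound 2, `Cc1c(OCCCCOc2cccc(C(=O)O)c2)ccc(C(=O)CC(C)C)c1C`, the entry in this assay reads "not determined" (no result reported), so no number stands for it. Compound 4, `Cc1cc(C(=O)O)ccc1OCCCCOc1ccc(C(=O)CC2CCCC2)c(O)c1C`, differs from compound 1 in one place: 4-carboxy-2-methylphenyl in place of (4-carboxyphenoxy)methyl on an oxygen on a saturated carbon. Among the compounds with values here, no step between measured compounds shows this change. The step of a 1.3-fold lower number from compound 1 to compound 4 (0.10 log units; within the scatter) is expected to stay within the scatter, because compound 3 gives 2050 nM with its own carboxyphenyl ring joined at that oxygen. Compound 4 is therefore expected to give 1500 nM in this assay, within a range from 600 nM to 4000 nM.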

Compound 4, half-maximal effective concentration: > 10000 nM
Compound 4: a limit, no number; the forecaster's own chance of this, stated with the estimate: 10%; middle value at least 6.6-fold (0.82 log units) away from the limit.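

In this assay, 4-carboxy-2-methylphenyl in place of (4-carboxyphenoxy)methyl on an oxygen on a saturated carbon gives an at least 5.2-fold higher number from compound 1 to compound 4 (0.71 log units; beyond the scatter). Within the data shown here, no earlier step touched this position, and this one shows that the group on this oxygen can decide the read-out. Compound 4 gives a limit of the assay, not a number: the limit of > 10000 nM in this assay, at which 1 of the 4 values shown sits.

The change shortens the link and adds a methyl at once, and the compounds shown do not separate the two. A plain 4-carboxyphenyl on this oxygen, without the methyl, would tell them apart.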